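A few compounds are considered here, and "the series" means these few. Any claim that something is new, unique, unknown or untested is made for them only; others in the source may bear on it.

Measured so far:
Compound 1 `CC(C)CSc1nc(N)nc2c1ncn2/C=C1/CC1(CO)CO`. In an ADME assay on HFF cells (Homo sapiens) for cytotoxicity, with a stated time of 8 days (a lower number here means that less compound is tolerated, a higher number that more compound is tolerated), compound 1 gives > 300000 nM, a limit of the assay rather than a number.
Compound 2 `Nc1nc(N2CCCC2)c2ncn(/C=C3/CC3(CO)CO)c2n1`. In this assay compound 2 gives > 300000 nM, again a limit of the assay and not a number.

Among the measured compounds shown here, compound 1 therefore stands only at a limit in this assay; the one further value shown is a limit too, so (the limit of > 300000 nM in this assay, at which 2 of the 2 values shown sit). For the measured compounds named here, the single measured step, a step that the two limits leave unreadable from compound 1 to compound 2, puts pyrrolidin-1-yl in place of isobutylsulfanyl on an aromatic carbon, and its size cannot be read because both ends sit at the limit.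

Compound 3 `CC(C)Sc1nc(N)nc2c1ncn2/C=C1/CC1(CO)CO` is still to be measured in this assay. It differs from compound 1 by isopropyl in place of isobutyl on a sulfur, so on the sulfur that carries the chain an isopropyl stands where the isobutyl stood.

Going by the values given here, no measured step bears on this change in a readable way; the only step in hand is unreadable, and both values sit at the limit. Nothing shown points to a step beyond the scatter, and the expectation is that compound 3 will also be tolerated up to the limit of this assay. Compound 3 is therefore estimated at 300000 nM, within 100000 nM to 300000 nM, which is expected to mean a step of a number no higher from compound 1 to compound 3 (the limit leaves the size open).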

Compound 3, half-maximal cytotoxic concentration: > 300000 nM
Compound 3: a limit, no number; the forecaster's own chance of this, stated with the estimate: 85%; the middle value sits exactly at the limit.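

Compound 3 adds no readable step: in this assay the steps among compound 1, compound 2 and compound 3 cannot be read, since each value is a limit of the assay, not a number: the limit of > 300000 nM in this assay, at which 3 of the 3 values shown sit. The compounds shown leave open the concentration at which any of them becomes cytotoxic, and whether the substituents differ in tolerance at all.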